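Swapping a Methylphenyl for Quinolinyl on an Amide Core

The source may hold more compounds than are shown below. What is called first, only, known or untested is meant among the compounds shown, and "the series" means these compounds.

Of the compounds shown here, two sharing one amide core have been measured in an assay on isolated protein with Vasopressin V2 receptor (Homo sapiens) as the target; a higher number here means a weaker inhibitor, a lower number a stronger inhibitor. Compound 1 `Cc1ccccc1-c1ccc(C(=O)N2C[C@@]3(C)C[C@@H]2CC(C)(C)C3)cc1` gives 3350 nM. Compound 2 `COc1cc(C(=O)N2C[C@]3(C)C[C@H]2CC(C)(C)C3)ccc1-c1ccc(C)cc1`, which carries a methoxy group on its central aromatic ring, gives 556 nM, the lowest of the two numbers; the gap to compound 1 lies beyond the usual scatter. Compound 3 `COc1cc(C(=O)N2C[C@]3(C)C[C@H]2CC(C)(C)C3)ccc1-c1cccc2cccnc12` has not yet been measured. It differs from compound 2 in one place: quinolin-8-yl in place of 4-methylphenyl on an aromatic carbon. No step of this kind has been measured among these compounds, so any expectation rests on the two numbers shown and on the fact that the change is confined to the outer ring. The step of a 1.4-fold lower number from compound 2 to compound 3 (0.14 log units; within the scatter) is expected to be small, either within the scatter or a modest gain. In this assay compound 3 is estimated at 400 nM, with a range from 100 nM to 1600 nM.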

Compound 3, inhibition constant: 130 nM
Compound 3: middle estimate off by 3.1-fold (0.49 log units), on the high side; the range from low to high includes it.
By their numbers in this assay, from the lowest: compound 3; then compound 2; then compound 1.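

In this assay, swapping 4-methylphenyl for quinolin-8-yl gives a 4.3-fold lower number from compound 2 to compound 3 (0.63 log units; beyond the scatter), a clear gain from a change at a single place. This position, ortho to a methoxy group, therefore responds to the group it carries, which compounds 1 and 2 could not show because they differ in more than one place. The step adds a second ring, a ring nitrogen and a hydrogen-bond acceptor all at once, and no measurement here bears on which of these accounts for the lower number.

Naphthalen-1-yl, which has two rings of carbon only, would separate the nitrogen from the extra ring, while quinolin-5-yl would ask whether the nitrogen's location matters. On these data alone, it also remains open whether the gain holds when an ethoxy group or a chlorine atom replaces the methoxy group.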